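Swapping pyrimidine for pyridine on a tetrahydroisoquinoline core

A few compounds are considered here, and "the series" means these few. Any claim that something is new, unique, unknown or untested is made for them only; others in the source may bear on it.

Measured compounds:
- compound 1, `N#Cc1ccc(N2CCc3cc(-c4cnc5ccccc5c4)ccc3C2)cc1C(F)(F)F`: > 30000 nM
- compound 2, `N#Cc1ccc(N2CCCc3c(-c4cccnc4)cccc32)cc1C(F)(F)F`: 13500 nM
- compound 3, `N#Cc1ccc(N2CCc3cc(-c4cncnc4)ccc3C2)cc1C(F)(F)F`: "not determined" (no result reported)

Of the compounds shown here, three have been tested in a functional assay on VCaP cells (Homo sapiens) for antiproliferative activity, read by CCK-8 assay, with a stated time of 6 days; a lower number here means a stronger inhibitor, a higher number a weaker inhibitor. Compound 1 gives only a limit there, > 30000 nM, which marks the edge of what the assay can report rather than a true number. Compound 2, which carries a different core, gives 13500 nM, a weak but measurable result. For compound 3 the entry in this assay reads "not determined" (no result reported), so no number is known for it. Going by the values given here, the one further value shown is the limit of compound 1 (the limit of > 30000 nM in this assay, at which 1 of the 3 values shown sits).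

Compound 4, `N#Cc1ccc(N2CCc3cc(-c4cccnc4)ccc3C2)cc1C(F)(F)F`, is still to be measured in this assay. It differs from compound 3 in one place: pyridin-3-yl in place of pyrimidin-5-yl on an aromatic carbon. Among the compounds with values here, with no number for compound 3, no step can be computed, so the expectation rests on the two measured compounds. Compound 4 is expected to be a weak inhibitor in this assay, estimated at 10000 nM, with a likely range from 3000 nM to 30000 nM.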

Compound 4, half-maximal inhibitory concentration: 2530 nM
The estimate for compound 4 lay 4.0-fold (0.60 log units) above the measured number; measured number below the stated range.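

Putting pyridin-3-yl in place of quinolin-3-yl on this aromatic carbon gives an at least 11-fold lower number from compound 1 to compound 4 (1.07 log units; beyond the scatter) in this assay, so the group held at this position clearly matters on the shared core. Going by these compounds, compound 1 gives only a limit, so this step is a minimum and its full size is unknown: the limit of > 30000 nM in this assay, at which 1 of the 4 values shown sits. Among the compounds shown on this core, compound 4 also provides the first exact number, 2530 nM, which gives later changes at this position a firm point of comparison.

Compound 3 has no reported result, so the step between pyrimidin-5-yl and pyridin-3-yl cannot be read. On these data alone, it also remains open whether a plain phenyl ring or a morpholine at this carbon would give a lower or higher number than compound 4.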